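Trimming an Alkyl Chain at the Detection Limit

The source may report more compounds than this note shows. Statements on the series, on what has been measured and on what is new or still open speak of the compounds shown alone.

Compound 3 `CCCCCCc1cn([C@H]2C[C@@H]3OP(=O)(O)OC[C@H]3O2)c(=O)[nH]c1=O` carries a hexyl group on the shared core. In a functional assay on Raji cells (Homo sapiens) (a higher number here means a weaker inhibitor, a lower number a stronger inhibitor), compound 3 reaches only the limit > 500 ug/mL, which is not a number. Compound 1 `CC(C)c1cn([C@H]2C[C@@H]3OP(=O)(O)OC[C@H]3O2)c(=O)[nH]c1=O`, with isopropyl, likewise gives the limit > 500 ug/mL in this assay. Compound 2 `CCCCCc1cn([C@H]2C[C@@H]3OP(=O)(O)OC[C@H]3O2)c(=O)[nH]c1=O`, with pentyl, also sits at the limit > 500 ug/mL. Because all three values rest at the limit (the limit of > 500 ug/mL in this assay, at which 3 of the 3 values shown sit), the steps a step that the two limits leave unreadable from compound 1 to compound 2, a step that the two limits leave unreadable from compound 1 to compound 3 and a step that the two limits leave unreadable from compound 2 to compound 3 cannot be read in size or direction. Compound 4 `CCCCc1cn([C@H]2C[C@@H]3OP(=O)(O)OC[C@H]3O2)c(=O)[nH]c1=O` differs from compound 3 by hydrogen in place of ethyl on a saturated chain carbon, four bonds along the chain from an aromatic carbon. Nothing measured here points either way, so compound 4 is expected to stay at the limit, the step that the limit leaves unreadable from compound 3 to compound 4 being an estimate only. The estimate for compound 4 is 800 ug/mL, between 300 ug/mL and 3000 ug/mL.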

Compound 4, concentration for 50% inhibition: 82 ug/mL
Compound 4: the middle estimate sits 9.8-fold (0.99 log units) above what was measured, outside the stated range (below it).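

In this assay, a lower number means a stronger inhibitor, and butyl in place of the longer chains gives an at least 6.0-fold lower number from compound 3 to compound 4 (0.78 log units; beyond the scatter) and an at least 6.0-fold lower number from compound 2 to compound 4 (0.78 log units; beyond the scatter), while butyl in place of isopropyl gives an at least 6.0-fold lower number from compound 1 to compound 4 (0.78 log units; beyond the scatter). This position on the shared core can therefore give measurable inhibition, and the outcome changes with the alkyl group placed there. Among these compounds, only compound 4 gives a number rather than a limit: the limit of > 500 ug/mL in this assay, at which 3 of the 4 values shown sit.

As far as these compounds go, the full size of each step remains open. So does whether a straight propyl chain, or a butyl chain ending in an amine, would give a lower number than compound 4.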